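Shortening the phenyl-bearing chain on the shared core

This account rests on a few compounds, and the source may have more. Where it says the series, first, only, none or still open, it means among the compounds named here.

Compound 1 `Cc1occc1-c1nnc2sc(CCCc3ccccc3)nn12`: 41%
Compound 2 `C(=C/c1nn2c(-c3ccncc3)nnc2s1)\c1ccco1`: 82%

In an assay for inhibition of histone-lysine N-methyltransferase, H3 lysine-79 specific (Homo sapiens), read by scintillation counting, with stated times of 15 min and 60 min, tested at 100 uM, in the presence of a further agent that is not named here (a lower number here means a weaker effect, a higher number a stronger effect of the compound at the concentration tested), compound 1 gives 41%, the lower of the two numbers shown, while compound 2 gives 82%, a gap beyond the scatter. Compound 3 `Cc1occc1-c1nnc2sc(CCc3ccccc3)nn12` has not yet been measured. It differs from compound 1 by phenyl in place of benzyl on a saturated chain carbon, two bonds along the chain from an aromatic carbon. Within the data shown here, no measured pair shows this change, so in this assay no step beyond the scatter is expected in either direction. Compound 3 is therefore expected to give about 38%, between 15% and 65%. Compound 3 thus carries an estimated step of a number 3 percentage points lower from compound 1 to compound 3 (within the scatter).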

Compound 3, a percentage reported as inhibition, at one concentration (the size of the read-out at that concentration, not a potency): 27%
For compound 3 the middle estimate is 11 percentage points above the measured one; the range from low to high includes it.
By their numbers in this assay, from the lowest: compound 3; then compound 1; then compound 2.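

In this assay, phenyl in place of benzyl on a saturated chain carbon, two bonds along the chain from an aromatic carbon, gives a number 14 percentage points lower from compound 1 to compound 3 (beyond the scatter). This is the only step shown at this position, and it shows that the shared core's phenyl-bearing chain is not indifferent to this small change. No measurement shown accounts for the step. Going by these compounds, whether a longer chain or an amine on the chain would raise or lower the number remains open. Compound 2 differs from these compounds in more than one place, so it cannot settle this.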